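The source may report more compounds than this note shows. Statements on the series, on what has been measured and on what is new or still open speak of the compounds shown alone.

Compound 1 (`O=C(CCCCN1CCCCC1)Nc1cc(-c2ccc(Cl)cc2)n[nH]1`) and compound 2 (`O=C(CCCCN1CCCCC1)Nc1cc(-c2ccc(C(F)(F)F)cc2)n[nH]1`) share a core and differ in one group. In an ADME assay for permeability, using PAMPA, with a stated time of 4 h, tested at 10 uM (a lower number here means that the compound crosses the layer more slowly, a higher number that the compound crosses the layer faster), compound 1 gives > 10 10^-6 cm/s, which is a limit of the assay and not a number. In this assay compound 2 gives > 10 10^-6 cm/s, which is also a limit and not a number. Compound 2 therefore stands at the limit of > 10 10^-6 cm/s in this assay, at which 2 of the 2 values shown sit, and it has no readable position relative to compound 1.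

The next change leads to compound 3 (`O=C(CCCCN1CCCCC1)Nc1cc(-c2ccc(Br)cc2)n[nH]1`), with bromo in place of trifluoromethyl on an aromatic carbon. Among the measured compounds shown here, the only measured step that bears on this change is a step that the two limits leave unreadable from compound 1 to compound 2, and it replaced chloro with trifluoromethyl. That step supplies neither a size nor a direction to carry over, so the expectation rests on the shared limit alone. The expected change is a step that the limit leaves unreadable from compound 2 to compound 3, with no shift beyond the usual scatter in either direction. A further limit is the likeliest report. The estimated value for compound 3 is 15 10^-6 cm/s, with an expected range from 8 10^-6 cm/s to 30 10^-6 cm/s.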

Compound 3, apparent permeability: > 10 10^-6 cm/s
Compound 3 gave a limit, no number (the forecaster's own chance of this, stated with the estimate: 75%); the middle value does not contradict the limit.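

In this assay, among the compounds shown here, compound 3 also gives a limit and not a number, so no step among compound 1, compound 2 and compound 3 can be read: the limit of > 10 10^-6 cm/s in this assay, at which 3 of the 3 values shown sit.

The compounds shown leave open whether chloro, trifluoromethyl and bromo differ at all in apparent permeability, and what number any of the three compounds would give.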